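From 3-fluorophenyl to 4-fluorophenyl in the series

This account rests on a few compounds, and the source may have more. Where it says the series, first, only, none or still open, it means among the compounds named here.

In an ADME assay for permeability, using PAMPA (a lower number here means that the compound crosses the layer more slowly, a higher number that the compound crosses the layer faster), compound 1 `CC(=O)N1CCC(C(=O)N2CCC(N3CCN(C(=O)c4cc(-c5ccccc5)nc(-c5ccc6[nH]ccc6c5)c4)CC3)CC2)CC1` gives 46.5 10^-6 cm/s. For the measured compounds named here, compound 2 `CC(=O)N1CCC(C(=O)N2CCC(N3CCN(C(=O)c4cc(-c5cccc(F)c5)nc(-c5ccc6[nH]ccc6c5)c4)CC3)CC2)CC1` gives 19.9 10^-6 cm/s, the lower of the two numbers so far.

Compound 3 `CC(=O)N1CCC(C(=O)N2CCC(N3CCN(C(=O)c4cc(-c5ccc(F)cc5)nc(-c5ccc6[nH]ccc6c5)c4)CC3)CC2)CC1` has the same atoms as compound 2, joined differently: 4-fluorophenyl in place of 3-fluorophenyl on an aromatic carbon. It carries 4-fluorophenyl in place of 3-fluorophenyl on an aromatic carbon of a six-membered aromatic ring with 1 nitrogen, next to the ring nitrogen.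

Going by the values given here, only one measured step bears on this change: a 2.3-fold lower number from compound 1 to compound 2 (0.37 log units; beyond the scatter), which is modest and beyond the scatter, for fluoro in place of hydrogen on an aromatic carbon. Among the compounds with values here, that step adds a fluorine rather than moving one, so it gives a scale but no direction, and no measured pair moves a fluorine. Compound 3 keeps the fluorine of compound 2, so no change beyond the scatter is expected in this assay. The expected step is a 1.1-fold higher number from compound 2 to compound 3 (0.04 log units; within the scatter). Compound 3 is estimated at 22 10^-6 cm/s, with an expected range of 10 10^-6 cm/s to 46 10^-6 cm/s.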

Compound 3, apparent permeability: 44.3 10^-6 cm/s
The estimate for compound 3 lay 2.0-fold (0.30 log units) below the measured number, and the stated range covers the measured number.
By their numbers in this assay, from the lowest: compound 2; then compounds 3 and 1 (each within the scatter of the next).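

In this assay, the place of the fluorine on this phenyl ring matters: a 2.2-fold higher number from compound 2 to compound 3 (0.35 log units; beyond the scatter), so 3-fluorophenyl and 4-fluorophenyl cannot be treated as interchangeable at this position on the six-membered aromatic ring, next to the ring nitrogen. The earlier step is a 2.3-fold lower number from compound 1 to compound 2 (0.37 log units; beyond the scatter) and it adds a fluorine. The new comparison is a 1.0-fold lower number from compound 1 to compound 3 (0.02 log units; within the scatter) and it also adds a fluorine, but it lies within the scatter, so among these three compounds only compound 2, with 3-fluorophenyl, stands apart from the others. No independent measurement among the data shown accounts for the difference between the two fluorine placements, and the step remains an observation on three compounds.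

On these data alone, it remains open whether a chlorine or a methoxy group would show the same dependence on placement, or whether the gap between 3-fluorophenyl and 4-fluorophenyl is particular to fluorine. As far as these compounds go, it is also open whether that gap would persist if the acetyl group at the far end of the shared core gave way to a longer chain or an amine.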